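A few compounds are considered here, and "the series" means these few. Any claim that something is new, unique, unknown or untested is made for them only; others in the source may bear on it.

Series notes. Compound 1 `C1=C2CCCC3CC1CCC23` has in an ADME assay (Gallus gallus) for cytotoxicity, read by microscopy, with a stated time of 24 h (a lower number here means that less compound is tolerated, a higher number that more compound is tolerated), the entry no result reported. Going by the values given here, compound 2 `O=C(O)C12CCCC3CC(CCC31)C2` is the only member with a number: in this assay compound 2 gives 10000000 nM, so it stands alone on the scale and no step between measured compounds can be drawn. Compound 3 `CNC(=O)C12CCCC3CC(CCC31)C2` carries the change (methylamino in place of hydroxy on a carbonyl carbon). Among the compounds with values here, with a single measured point there is no step to rest on; the expected step, a 2.0-fold lower number from compound 2 to compound 3 (0.30 log units; within the scatter), is small, at most a slight shift toward less compound tolerated, and not clearly beyond the scatter. For compound 3 the estimate in this assay is 5000000 nM, within 1000000 nM to 10000000 nM.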

Compound 3, minimum cytotoxic concentration: 750000 nM
The estimate for compound 3 lay 6.7-fold (0.82 log units) above the measured number; measured number outside the range, below it.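

In this assay methylamino in place of hydroxy on a carbonyl carbon gives a 13-fold lower number from compound 2 to compound 3 (1.12 log units; beyond the scatter) and so this place on the shared core is shown to matter, with the change from carboxy to methylcarbamoyl moving the read-out toward less compound tolerated. This rests on one pair of compounds only. Nothing measured here bears on the reason for the shift. From the compounds shown here alone, whether ethylamino, dimethylamino or an unsubstituted amino group in place of methylamino would move the number further stays open. Compound 1 has no number, so steps to it cannot be read.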